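Extending the alkyl chain from hexyl toward octyl

A few compounds are considered here, and "the series" means these few. Any claim that something is new, unique, unknown or untested is made for them only; others in the source may bear on it.

In an assay on HeLa cells for inhibition of sphingosine-1-phosphate transporter SPNS2 (Mus musculus), read by LC-MS, tested at 2 uM (a higher number here means more inhibition at the concentration tested (going by the name of the read-out), a lower number less inhibition), compound 3 `CCCCCCc1ccc(-c2noc(CCCN)n2)cc1` gives 55%. Compound 2 `CCCCCCCCCCc1ccc(-c2noc(CN)n2)cc1` gives 62% and compound 1 `CCCCCCCCCCc1ccc(-c2noc(C3CNC3)n2)cc1` gives 65%; the gaps from compound 3 to each of these lie within the scatter, so the three read-outs cannot be told apart. Compound 4 `CCCCCCCCc1ccc(-c2noc(CCCN)n2)cc1` differs from compound 3 by ethyl in place of hydrogen on a saturated chain carbon, six bonds along the chain from an aromatic carbon. Among the measured compounds shown here, the only measured step, a number 3 percentage points lower from compound 1 to compound 2 (within the scatter), alters the amine head rather than the chain, so no measured step bears on this change. The chain of compound 4 sits between that of compound 3 and those of compounds 1 and 2, all of which read alike, so no step beyond the scatter is expected. Compound 4 is therefore estimated at 60%, with a range of 45% to 75%, an expected step of a number 5 percentage points higher from compound 3 to compound 4 (within the scatter).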

Compound 4, a percentage reported as inhibition, at one concentration (the size of the read-out at that concentration, not a potency): 70%
For compound 4 the middle estimate is 10 percentage points below the measured one; measured number inside the range.
By their numbers in this assay, from the lowest: compounds 3, 2, 1 and 4 (each within the scatter of the next, the first and the last beyond it).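

With the amine head unchanged, ethyl in place of hydrogen on a saturated chain carbon, six bonds along the chain from an aromatic carbon, gives a number 15 percentage points higher from compound 3 to compound 4 (beyond the scatter). Among the compounds shown here, this is the first step here beyond the scatter, and it shows that lengthening the chain at this position, with nothing else changed, can alter the inhibition read-out. No measurement here explains the rise.

On these data alone, whether a dodecyl chain on the same amine head would move the number further remains open. So does whether ethyl at this position has a similar effect with an aminomethyl or azetidin-3-yl head.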